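From Bromo to Methoxy: An Untested Swap

The compounds below may be only part of what the source reports. "The series", "measured", "known", "first", "only" and "open" are said of these compounds alone.

Among the compounds with values here, compound 2 `S=C(N/N=C/c1ccc2ccccc2n1)Nc1ccc(Br)cc1` gives 27500 nM in a functional assay on HL-60 cells (Homo sapiens) for antiproliferative activity, read by sulforhodamine B assay, with a stated time of 72 h (on this read-out higher numbers stand for weaker inhibition and lower numbers for stronger inhibition), the highest of the two numbers known so far. Within the data shown here, its only neighbour, compound 1 `N#Cc1ccc(NC(=S)N/N=C/c2ccc3ccccc3n2)cc1`, gives 4660 nM in this assay, and the step of a 5.9-fold higher number from compound 1 to compound 2 (0.77 log units; beyond the scatter) is the sole measured comparison. Compound 3 `COc1ccc(NC(=S)N/N=C/c2ccc3ccccc3n2)cc1` is not yet measured; it differs from compound 2 by methoxy in place of bromo on an aromatic carbon. Among the measured compounds shown here, no measured step swaps bromo for methoxy, so the cyano-to-bromo step offers only weak guidance. The step of a 1.4-fold lower number from compound 2 to compound 3 (0.14 log units; within the scatter) is therefore expected to stay within the scatter. Compound 3 is estimated at 20000 nM, within a range from 6000 nM to 60000 nM.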

Compound 3, half-maximal inhibitory concentration: 43800 nM
Compound 3: the middle estimate sits 2.2-fold (0.34 log units) below what was measured; the measured number falls inside the stated range.
By their numbers in this assay, from the lowest: compound 1; then compounds 2 and 3 (each within the scatter of the next).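

On this aromatic carbon, swapping bromo for methoxy gives a 1.6-fold higher number from compound 2 to compound 3 (0.20 log units; within the scatter) in this assay and so does not separate the two groups. The cyano group now stands apart from both of them, as the step of a 9.4-fold higher number from compound 1 to compound 3 (0.97 log units; beyond the scatter) joins the earlier step of a 5.9-fold higher number from compound 1 to compound 2 (0.77 log units; beyond the scatter) in lying beyond the scatter. Nothing measured here gives a reason for this gap.

From the compounds shown here alone, whether an amine or a carboxylic acid here would fall nearer compound 1 or compound 3 remains open. So does whether a longer chain, such as ethoxy, would match methoxy.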